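Swapping the Aryl Group on the Shared Core

The source may report more compounds than this note shows. Statements on the series, on what has been measured and on what is new or still open speak of the compounds shown alone.

This study measures how strongly each compound stops human liver cancer cells from growing, in a functional assay on HepG2 cells (Homo sapiens) for cytotoxicity, read by MTT assay, with a stated time of 72 h; a lower number here means a stronger inhibitor, a higher number a weaker inhibitor. Of the compounds shown here, three have been tested so far. Compound 1 `Cn1ccc2c(Oc3ccc(NC(=O)c4nn(-c5ccc(Br)cc5F)ccc4=O)cc3)ccnc21` gives 31200 nM. Compound 2 `Cn1ccc2c(Oc3ccc(NC(=O)c4nn(-c5ccccc5)ccc4=O)cc3F)ccnc21` reaches only a limit of the measurement, > 60000 nM; the evidence here is the limit of > 60000 nM in this assay, at which 1 of the 3 values shown sits. Compound 3 `Cc1ccc(-n2nc(C(=O)Nc3ccc(Oc4ncnc5[nH]ccc45)cc3)c(C)cc2=O)cc1` gives 7460 nM, the lowest of the two numbers, and the nearest value, that of compound 1, is higher by a step beyond the usual scatter.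

Compound 4 `Cc1cc(=O)n(-c2ccc(Br)cc2F)nc1C(=O)Nc1ccc(Oc2ncnc3[nH]ccc23)cc1` differs from compound 3 in one place: 4-bromo-2-fluorophenyl in place of 4-methylphenyl on an aromatic nitrogen. Among the measured compounds shown here, no measured pair shows this exact change on the shared core. Compound 1 carries the same 4-bromo-2-fluorophenyl group on a different core and sits well above compound 3, while compound 2, with a plain phenyl on that other core, reaches only a limit. These values come from a different core than that of compound 3. They hint at a direction only. The expectation is a moderate weakening, a 1.7-fold higher number from compound 3 to compound 4 (0.24 log units; within the scatter), beyond the scatter but not large. Compound 4 is therefore expected to give about 13000 nM, with a plausible range from 4000 nM to 45000 nM.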

Compound 4, half-maximal inhibitory concentration: 3660 nM
Estimate against measurement, compound 4: 3.6-fold (0.55 log units) above; measured number outside the range, below it.
By their numbers in this assay, from the lowest: compound 4; then compound 3; then compound 1. At a limit, above all of these: compound 2.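

Among the compounds shown here, on the shared core, 4-bromo-2-fluorophenyl in place of 4-methylphenyl on the aromatic nitrogen gives a 2.0-fold lower number from compound 3 to compound 4 (0.31 log units; beyond the scatter) in this assay and thus provides the first direct evidence that this position responds to a change of aryl group, though only modestly. The earlier compounds shown here could not show this: compound 1 and compound 2 sit on a different core and do not form a one-place pair with compound 3. Both groups in this step are six-membered aromatic rings of carbon only, so the ring type stays the same while the methyl leaves and the bromine and fluorine enter, but nothing measured here explains why the number falls.

The bromine and fluorine enter together and the methyl leaves in the same step, so the shared core does not yet show what each contributes, a question that a 4-bromophenyl or a 2-fluorophenyl group could address. Also open, from the compounds shown here alone, is how the number would respond to a group carrying an amine or a carboxylic acid on this ring, or to a longer chain in place of the ring.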